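A Heteroaryl Swap on the Most Stable Compound

The compounds below may be only part of what the source reports. "The series", "measured", "known", "first", "only" and "open" are said of these compounds alone.

Measurements in an ADME assay on microsomes from liver (Homo sapiens) for metabolic stability, with a stated time of 60 min (on this read-out lower numbers stand for a less stable compound and higher numbers for a more stable compound), exist for three compounds. Compound 1 `Cc1ccc(NC(=O)CC(CCO)c2nnc(CCCC(C)C)n2C2CC2)c(C)c1` gives 21%. Within the data shown here, compound 2 `CC(=O)NCCC(CC(=O)Nc1ccc(C)cc1C)c1nnc(CCCC(C)C)n1C1CC1` gives 39%, and the change a number 18 percentage points higher from compound 1 to compound 2 (beyond the scatter) is the only measured step between compounds that differ in one place. Compound 3 `Cc1ccc(NC(=O)C[C@H](CCC(=O)O)c2noc(-c3ccc(CC(C)C)cc3)c2C2CC2)c(Cl)c1` gives 80%, the highest of the three numbers; its gap to compound 2 and its larger gap to compound 1 are both beyond the scatter.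

Compound 4 `Cc1ccc(NC(=O)C[C@H](CCC(=O)O)c2noc(-c3cc(CCC(C)C)on3)c2C2CC2)c(Cl)c1` differs from compound 3 by 5-isopentyl-1,2-oxazol-3-yl in place of 4-isobutylphenyl on an aromatic carbon, on an aromatic carbon of a five-membered aromatic ring with one nitrogen and one oxygen. Among the measured compounds shown here, the measured step from compound 1 to compound 2 concerns a different change on a different core, so no measured step bears directly on this swap. The expectation therefore leans on compound 3 alone, allowing a modest fall: the estimated change is a number 15 percentage points lower from compound 3 to compound 4 (beyond the scatter). Compound 4 is expected to give about 65%, within a range from 40% to 90%.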

Compound 4, percent of the compound remaining: 79%
The estimate for compound 4 lay 14 percentage points below the measured number, within the range that was stated.
By their numbers in this assay, from the lowest: compound 1; then compound 2; then compounds 4 and 3 (each within the scatter of the next).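

At this place, on an aromatic carbon of a five-membered aromatic ring with 1 nitrogen and 1 oxygen, 4-isobutylphenyl can be exchanged for 5-isopentyl-1,2-oxazol-3-yl with no change that can be told apart in this assay: the step is a number 1 percentage points lower from compound 3 to compound 4 (within the scatter). The earlier compounds shown here offered no comparison at this place, and this step shows that a ring of carbon only, with 0 hydrogen-bond acceptors, and a ring with 2 hetero atoms and 2 hydrogen-bond acceptors can read alike here. No available evidence explains why these two groups read alike.

Still open, from the compounds shown here alone, is whether a much shorter group such as methyl, or a chain ending in an amine, would hold the number at this place. Also open, going by these compounds, is whether the same exchange would read alike on the core of compound 1.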